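A few compounds are considered here, and "the series" means these few. Any claim that something is new, unique, unknown or untested is made for them only; others in the source may bear on it.

Measured so far in a functional assay on Jurkat cells (Homo sapiens) for inhibition; a higher number here means a weaker inhibitor, a lower number a stronger inhibitor:

compound 1, `CC(C)c1cc(OCC(=O)[C@H](CC(=O)O)NC(=O)[C@@H](NC(=O)COc2cccc3ccccc23)C(C)C)no1` — in this assay compound 1 gives > 200000 nM, which is a limit of the assay and not a number.
compound 2, `CC(C)[C@H](NC(=O)COc1cccc2ccccc12)C(=O)N[C@@H](CC(=O)O)C(=O)COc1cc(C(F)(F)F)ncn1` — in this assay compound 2 gives > 200000 nM, again a limit of the assay and not a number.
compound 3, `CC(C)[C@H](NC(=O)COc1cccc2ccccc12)C(=O)N[C@@H](CC(=O)O)C(=O)COc1cncc2ccccc12` — in this assay compound 3 gives 166000 nM.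

Going by the values given here, compound 3 thus stands as the only actual number; the other two values sit at the limit of > 200000 nM in this assay, at which 2 of the 3 values shown sit. Every measured step changes the aromatic group on the oxygen on the saturated carbon: an at least 1.2-fold lower number from compound 1 to compound 3 (0.08 log units; that floor lies within the scatter) and an at least 1.2-fold lower number from compound 2 to compound 3 (0.08 log units; that floor lies within the scatter) are floors that lie within the scatter, and a step that the two limits leave unreadable from compound 1 to compound 2.

Compound 4, `CC(C)[C@H](NC(=O)COc1cccc2ccccc12)C(=O)N[C@@H](CC(=O)O)C(=O)COc1[nH]cnc2nncc1-2`, continues the same kind of change: a group of 9 heavy atoms (5 carbon, 4 nitrogen; one five-membered aromatic ring with 2 hetero atoms, one six-membered aromatic ring with 2 hetero atoms) in place of a group of 10 heavy atoms (9 carbon, 1 nitrogen; one six-membered aromatic ring of carbon only, one six-membered aromatic ring with 1 hetero atom), on an oxygen on a saturated carbon. Among the compounds with values here, none of the measured steps at this position gave a readable movement beyond the scatter, so no step beyond the scatter is expected here either, and a further limit is a real possibility. Compound 4 is estimated at 170000 nM in this assay, within 60000 nM to 500000 nM. The expected step is a 1.0-fold higher number from compound 3 to compound 4 (0.01 log units; within the scatter).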

Compound 4, half-maximal inhibitory concentration: 161000 nM
Estimate against measurement, compound 4: 1.1-fold (0.02 log units) above; the range from low to high includes it.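

In this assay, the series now has a step between two actual numbers rather than limits: a 1.0-fold lower number from compound 3 to compound 4 (0.01 log units; within the scatter). Replacing isoquinolin-4-yl with a group that has one five-membered and one six-membered aromatic ring, four nitrogens and a hydrogen-bond donor therefore gives no readable movement at this position. The other two steps, an at least 1.2-fold lower number from compound 2 to compound 4 (0.09 log units; that floor lies within the scatter) and an at least 1.2-fold lower number from compound 1 to compound 4 (0.09 log units; that floor lies within the scatter), are floors within the scatter, so they do not separate compound 4 from compound 1 or compound 2, whose values remain limits of the assay: the limit of > 200000 nM in this assay, at which 2 of the 4 values shown sit.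

From the compounds shown here alone, it remains open whether another kind of group on this oxygen, such as a plain phenyl ring or a piperidine, would give a step beyond the scatter. Going by these compounds, it is equally open whether this insensitivity would hold after a change elsewhere in the shared core.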